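Swapping an Oxygen-Nitrogen Side Group for Propyl

This account rests on a few compounds, and the source may have more. Where it says the series, first, only, none or still open, it means among the compounds named here.

Measured compounds:
- compound 1, `CC1(C)[C@@H](Cn2nnc3c(N)nc(N)nc32)CC[C@@]1(C)CO`: > 200000 nM
- compound 2, `CCCCCC(=O)O[C@@H]1[C@H](OC(=O)CCCCC)CO[C@@H](OC)[C@@]1(F)n1ccc(=O)[nH]c1=O`: 40000 nM
- compound 3, `O=c1[nH]c(=O)n([C@H]2C[C@H](O)[C@@H](CO)O2)cc1/C=N/O`: 15500 nM

In an ADME assay on L1210/0 cells (Mus musculus) for cytotoxicity, with a stated time of 48 h (on this read-out lower numbers stand for stronger inhibition and higher numbers for weaker inhibition), compound 1 reports only a limit, > 200000 nM, not a number. In this assay compound 2 gives 40000 nM, and compound 3 gives 15500 nM, the lowest of the two numbers shown, with the gap to compound 2 beyond the usual scatter. Compound 4, `CCCc1cn([C@H]2C[C@H](O)[C@@H](CO)O2)c(=O)[nH]c1=O`, is not yet measured. It differs from compound 3 in one place: a group of 3 heavy atoms (3 carbon; no ring) in place of a group of 3 heavy atoms (1 carbon, 1 nitrogen, 1 oxygen; no ring), on an aromatic carbon. The group that leaves sits on an aromatic carbon; propyl takes its place. Going by the values given here, no pair of measured compounds shows such a change, so the step is a guess. In this assay compound 4 is expected to be weaker, a step of a 3.2-fold higher number from compound 3 to compound 4 (0.51 log units; beyond the scatter), with an estimate of 50000 nM and a range from 10000 nM to 300000 nM.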

Compound 4, half-maximal inhibitory concentration: > 200000 nM
Compound 4: no number, only a limit (the forecaster's own chance of this, stated with the estimate: 25%); at least 4.0-fold (0.60 log units) between middle value and limit.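

In this assay, putting propyl in place of the side group on this aromatic carbon gives an at least 12-fold higher number from compound 3 to compound 4 (1.11 log units; beyond the scatter), so the group at this one place strongly shapes the read-out. Compound 4 reports only a limit, > 200000 nM, not a number. The step therefore has a floor but no known size, because the read-out ends there: the limit of > 200000 nM in this assay, at which 2 of the 4 values shown sit.

The compounds shown leave open whether another group here, such as an amine, a carboxylic acid or a longer chain, would match compound 3 or surpass it. They also cannot tell which part of the group that leaves counts: its nitrogen, its oxygen or its double bond.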